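A Cyclopropyl Urea Analogue and Its Expected Cytotoxicity

A few compounds are considered here, and "the series" means these few. Any claim that something is new, unique, unknown or untested is made for them only; others in the source may bear on it.

Compound 1 `c1cc2cc(-c3nc(N4CC5CCC(C4)O5)c4sccc4n3)ccc2[nH]1`: 1350 nM
Compound 2 `CNC(=O)Nc1ccc(-c2nc(N3CC4CCC(C3)O4)c3sc(CN4CCN(S(C)(=O)=O)CC4)cc3n2)cc1`: 120 nM
Compound 3 `O=C(Nc1ccc(-c2nc(N3CC4CCC(C3)O4)c3sccc3n2)cc1)Nc1cccnc1`: 27 nM

In a functional assay on LNCaP cells (Homo sapiens) for cytotoxicity (on this read-out higher numbers stand for weaker inhibition and lower numbers for stronger inhibition), compound 2 gives 120 nM, the second highest of the three numbers. Compound 3, at 27 nM, stands beyond the scatter below it, while compound 1, at 1350 nM, stands beyond the scatter above it.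

Compound 4 `CS(=O)(=O)N1CCN(Cc2cc3nc(-c4ccc(NC(=O)NC5CC5)cc4)nc(N4CC5CCC(C4)O5)c3s2)CC1` differs from compound 2 by cyclopropyl in place of methyl on an amide-type nitrogen. For the measured compounds named here, no comparable pair among the measured compounds shows what this exchange does, so the expectation rests on compound 2 alone. The estimated step of a 1.4-fold lower number from compound 2 to compound 4 (0.15 log units; within the scatter) is expected to be small, at most a modest lowering that may not exceed the scatter. Compound 4 is therefore expected to give 85 nM, with a range from 30 nM to 250 nM.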

Compound 4, half-maximal inhibitory concentration: 32 nM
Compound 4: the middle estimate sits 2.7-fold (0.42 log units) above what was measured; the range from low to high includes it.
By their numbers in this assay, from the lowest: compounds 3 and 4 (each within the scatter of the next); then compound 2; then compound 1.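

In this assay, for the compounds shown here, cyclopropyl in place of methyl on the amide-type nitrogen gives a 3.8-fold lower number from compound 2 to compound 4 (0.57 log units; beyond the scatter), the first reading of this exchange. It shows that this position takes the larger group, with its three-membered ring, and that inhibition grows stronger rather than weaker. No measurement shown accounts for this gain. Going by these compounds, whether ethyl, isopropyl or cyclobutyl on this nitrogen would lower the number further remains open. This single pair also cannot show whether the exchange would give a similar step on other compounds.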